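The source may report more compounds than this note shows. Statements on the series, on what has been measured and on what is new or still open speak of the compounds shown alone.

Measured so far in a functional assay on the whole organism with Rattus norvegicus as the target, at a dose of 3 mg/kg by the oral route; a higher number here means a stronger effect of the compound at the dose given, a lower number a weaker effect:
compound 1, `COc1ccc(-c2cc(OC)cc(C(=O)Nc3nn[nH]n3)n2)cc1`, gives 60%;
compound 2, `COc1cccc(-c2cc(C)cc(C(=O)Nc3nn[nH]n3)n2)c1`, gives 65%;
compound 3, `COc1ccc(-c2cc(C)cc(C(=O)Nc3nn[nH]n3)n2)cc1`, gives 43%.

Compound 2 and compound 1 differ in more than one place, so the difference between their two cores is not broken down here. Compound 4, `Cc1cccc(-c2cc(C)cc(C(=O)Nc3nn[nH]n3)n2)c1`, is not yet measured; it differs from compound 2 by methyl in place of methoxy on an aromatic carbon. A change of the same kind, (methyl in place of methoxy on an aromatic carbon), links compound 1 to compound 3, where this assay moved by a number 17 percentage points lower from compound 1 to compound 3 (beyond the scatter). The surroundings are not identical: in compound 3 the place is on a six-membered aromatic ring with 1 nitrogen, meta to a (2H-tetrazol-5-yl)carbamoyl group and meta to a 4-methoxyphenyl group, opposite the ring nitrogen; in compound 4 it is on a ring of carbon only, meta to a large group. Among the compounds with values here, only one earlier step of this kind is known, so the expectation rests loosely on it: from compound 2 to compound 4 a step of about a number 15 percentage points lower from compound 2 to compound 4 (beyond the scatter) is expected. Compound 4 is accordingly estimated at 50%, most likely between 30% and 70%.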

Compound 4, a percentage reported as inhibition, in the whole organism at one dose (the size of the read-out at that dose, not a potency): 61%
Estimate against measurement, compound 4: 11 percentage points below; the measured number falls inside the stated range.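

In this assay, methyl in place of methoxy on the ring of carbon only gives a number 4 percentage points lower from compound 2 to compound 4 (within the scatter), so this step shows no real change between the two compounds. Set beside the earlier case of the same change, the new step does not stand apart from it: the same change on two cores in this assay, a number 17 percentage points lower (beyond the scatter) from compound 1 to compound 3 and a number 4 percentage points lower (within the scatter) from compound 2 to compound 4, 13 percentage points apart, within the scatter of two such steps The change may therefore carry over from one core to another with a similar result, but two pairs are too few to establish this, and they do not show how large any shared effect would be.

The compounds shown carry only methoxy or methyl at these places. From the compounds shown here alone, how a chlorine, an amine or a longer chain there would read in this assay remains open.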